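Adding a Methoxy Group to Compound 3

A few compounds are considered here, and "the series" means these few. Any claim that something is new, unique, unknown or untested is made for them only; others in the source may bear on it.

Of the compounds shown here, three built on a shared core have been measured in a functional assay on HeLa cells (Homo sapiens) for antiproliferative activity, read by MTT assay, with a stated time of 48 h (on this read-out higher numbers stand for weaker inhibition and lower numbers for stronger inhibition), and their values sit close together. Compound 3 (`Oc1ccc2ccccc2c1C(Nc1nc2ccccc2s1)c1cn(-c2ccccc2)nc1-c1ccccc1`) gives 17300 nM and stands within the usual scatter of both others. Compound 1 (`Cc1ccc2nc(NC(c3cn(-c4ccccc4)nc3-c3cccc(Cl)c3)c3c(O)ccc4ccccc34)sc2c1`) gives 9430 nM and compound 2 (`Cc1cc2nc(NC(c3cn(-c4ccccc4)nc3-c3ccc([N+](=O)[O-])cc3)c3c(O)ccc4ccccc34)sc2cc1C`) gives 14700 nM in this assay as well.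

The next compound, compound 4 (`COc1ccc(-c2nn(-c3ccccc3)cc2C(Nc2nc3ccccc3s2)c2c(O)ccc3ccccc23)cc1`), differs from compound 3 in one place: methoxy in place of hydrogen on an aromatic carbon, para to a large group, which turns phenyl to 4-methoxyphenyl (methoxy in place of hydrogen on an aromatic carbon). Within the data shown here, no measured pair shows this change alone, since compound 1 and compound 2 each differ from compound 3 in more than one place. Even so, compound 1 at 9430 nM and compound 2 at 14700 nM both stay within the scatter of compound 3, and that narrow spread is the only ground for an expectation here. The estimated step of a 1.3-fold lower number from compound 3 to compound 4 (0.12 log units; within the scatter) is small, leaning slightly toward stronger inhibition and not expected to pass beyond the scatter. Compound 4 is estimated at 13000 nM with an expected range from 5500 nM to 30000 nM once measured.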

Compound 4, half-maximal inhibitory concentration: 9340 nM
The estimate for compound 4 lay 1.4-fold (0.14 log units) above the measured number, within the range that was stated.
By their numbers in this assay, from the lowest: compounds 4, 1, 2 and 3 (each within the scatter of the next).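

Among these compounds, the first comparison in this assay that turns on one place alone reads a 1.9-fold lower number from compound 3 to compound 4 (0.27 log units; within the scatter), so phenyl to 4-methoxyphenyl, with methoxy entering para to a large group on a six-membered aromatic ring of carbon only, gives a step that stays inside the usual scatter. The earlier compounds shown here could show only a narrow spread of values across structures differing in more than one place, whereas this pair ties a step of that size to this single change at this position, and a single pair is all it rests on. Nothing available bears on what lies behind the size of this step.

Among the compounds shown here, whether an amine, a carboxylic acid or a longer chain such as butoxy in this same place would give a step that passes beyond the scatter remains open, since methoxy is the only group here that replaces hydrogen at this position. Steps from compound 3 to compound 1 and to compound 2 cannot be read, as each of these compounds differs from compound 3 in more than one place.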